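Thromboxane Synthase Inhibitors: From Phenylsulfanyl to Hydroxycyclopentyl

The compounds below may be only part of what the source reports. "The series", "measured", "known", "first", "only" and "open" are said of these compounds alone.

Measured compounds in an assay (Equus caballus) for inhibition of Thromboxane-A synthase (Homo sapiens), using microsomes; a higher number here means a weaker inhibitor, a lower number a stronger inhibitor:
Compound 1 `CC(C)(O)C(CCC/C=C(\c1ccccc1)c1cccnc1)C(=O)O`, where compound 1 gives 42 nM
Compound 2 `COCC(CCC/C=C(\c1ccccc1)c1cccnc1)C(=O)O`, where compound 2 gives 41 nM
Compound 3 `O=C(O)C(CCC/C=C(\c1ccccc1)c1cccnc1)Sc1ccccc1`, where compound 3 gives 33 nM

Compound 3 holds the lowest of the three numbers in this assay, yet its neighbours sit within the scatter of it: a 1.2-fold lower number from compound 2 to compound 3 (0.09 log units; within the scatter) and a 1.3-fold lower number from compound 1 to compound 3 (0.10 log units; within the scatter). The same holds between the other two, since a 1.0-fold lower number from compound 1 to compound 2 (0.01 log units; within the scatter). Three different groups on the same chain carbon thus give indistinguishable numbers.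

Compound 4 `O=C(O)C(CCC/C=C(\c1ccccc1)c1cccnc1)C1(O)CCCC1` carries one further change: 1-hydroxycyclopentyl in place of phenylsulfanyl on a saturated chain carbon bound to a carbonyl carbon and a saturated chain carbon. Among the measured compounds shown here, the step bearing most on it is the one from compound 1, which carries a 1-hydroxy-1-methylethyl group, another tertiary alcohol, and that step was a 1.3-fold lower number from compound 1 to compound 3 (0.10 log units; within the scatter). Reversing a change of that kind, and given that none of the three measured steps left the scatter, no step beyond the scatter is expected in this assay. Compound 4 is therefore estimated at 40 nM, within a range of 18 nM to 90 nM. This estimate corresponds to an expected step of a 1.2-fold higher number from compound 3 to compound 4 (0.08 log units; within the scatter).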

Compound 4, half-maximal inhibitory concentration: 65 nM
Estimate against measurement, compound 4: 1.6-fold (0.21 log units) below; the range from low to high includes it.
By their numbers in this assay, from the lowest: compounds 3, 2, 1 and 4 (each within the scatter of the next).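

In this assay, among the compounds shown here, 1-hydroxycyclopentyl joins the other three groups on the saturated chain carbon bound to a carbonyl carbon and a saturated chain carbon, and no step leaves the scatter, whether it replaces phenylsulfanyl (a 2.0-fold higher number from compound 3 to compound 4 (0.29 log units; within the scatter)), methoxymethyl (a 1.6-fold higher number from compound 2 to compound 4 (0.20 log units; within the scatter)) or the open-chain tertiary alcohol 1-hydroxy-1-methylethyl (a 1.5-fold higher number from compound 1 to compound 4 (0.19 log units; within the scatter)). The four groups thus include a six-membered aromatic ring, a five-membered non-aromatic ring and two groups with no ring, yet none of these changes separates from the others at this position. No supporting evidence bears on why these numbers stay so close.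

The compounds shown leave open whether an amine, a second carboxylic acid or a longer chain on this carbon would give a step beyond the scatter. All four share the same core, so they say nothing about changes elsewhere in it.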